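Dichlorophenyl sulfonyl variant of an inactive hydrazide pair

The source may hold more compounds than are shown below. What is called first, only, known or untested is meant among the compounds shown, and "the series" means these compounds.

Compound 1 `CC(=O)Nc1ccc(S(=O)(=O)NNC(=O)c2cccnc2Nc2ccc(Cl)cc2)cc1` was tested in a functional assay on UACC-62 cells (Homo sapiens) for antiproliferative activity; a higher number here means a weaker inhibitor of growth, a lower number a stronger inhibitor of growth. In this assay compound 1 gives only a limit, > 100000 nM, and not a number. A related compound, compound 2 `O=C(NNS(=O)(=O)c1ccc(F)cc1)c1cccnc1Nc1ccc(Cl)cc1Cl`, was tested in the same way. In this assay compound 2 likewise gives only a limit, > 100000 nM. Going by the values given here, both values therefore sit at the limit of > 100000 nM in this assay, at which 2 of the 2 values shown sit, so compound 1 stands at the limit together with the only other measured compound, and no measured step is available. Compound 3 `O=C(NNS(=O)(=O)c1ccc(Cl)cc1Cl)c1cccnc1Nc1ccc(Cl)cc1` differs from compound 1 by 2,4-dichlorophenyl in place of 4-acetamidophenyl on a sulfonyl sulfur, in words 2,4-dichlorophenyl in place of 4-acetamidophenyl on a sulfonyl sulfur. Among the compounds with values here, with no measured step to lean on, the expected change from compound 1 to compound 3 in this assay is a number no higher from compound 1 to compound 3 (the limit leaves the size open), that is, none beyond the scatter. Compound 3 is accordingly estimated at 100000 nM, with a range from 30000 nM to 300000 nM, most likely again reported as a limit.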

Compound 3, concentration for total growth inhibition: 75900 nM
The estimate for compound 3 lay 1.3-fold (0.12 log units) above the measured number; measured number inside the range.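

In this assay compound 3 gives 75900 nM, the first number rather than a limit among the compounds shown, and it shows that the group on the sulfonyl sulfur can bring a reading inside the range of the assay. Going by these compounds, putting 2,4-dichlorophenyl in place of 4-acetamidophenyl on a sulfonyl sulfur gives an at least 1.3-fold lower number from compound 1 to compound 3 (0.11 log units; that floor lies within the scatter), and this is only a floor, so the true size of the change remains unknown. The other two values remain limits of the assay: the limit of > 100000 nM in this assay, at which 2 of the 3 values shown sit.

The compounds shown leave open how a plain phenyl, a 4-aminophenyl or a longer alkyl chain on the sulfonyl sulfur would read in this assay. Compound 2 differs from compound 3 in more than one place, and it gives no reading of either chlorine alone.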